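The compounds below may be only part of what the source reports. "The series", "measured", "known", "first", "only" and "open" are said of these compounds alone.

Within the data shown here, compound 2 `CCC1CCCN(C(=O)CN2CN(c3ccccc3)C3(CCN(C(=O)c4ccc(C(C)(C)C)cc4)CC3)C2=O)C1` is the only compound here with a number to show. In an assay on HEK293 cells for displacement of a labelled ligand from NPC1-like intracellular cholesterol transporter 1 (Homo sapiens) (a higher number here means a weaker inhibitor, a lower number a stronger inhibitor), compound 2 gives 3900 nM. Compound 1 `COC(=O)CCCNC(=O)CN1CN(c2ccccc2)C2(CCN(C(=O)c3ccc(C(C)(C)C)cc3)CC2)C1=O` has in this assay only "not determined" (no result reported), so nothing can be said of where it stands. Compound 3 `CC(C)(C)c1ccc(C(=O)N2CCC3(CC2)C(=O)N(CC(=O)NCCCCO)CN3c2ccccc2)cc1` differs from compound 2 by (4-hydroxybutyl)amino in place of 3-ethylpiperidin-1-yl on a carbonyl carbon. Among the measured compounds shown here, no measured pair shows a step of this kind, so the direction rests on the change alone. A step beyond the usual scatter and toward the weaker side is expected, roughly a 2.1-fold higher number from compound 2 to compound 3 (0.31 log units; beyond the scatter). Compound 3 is therefore estimated at 8000 nM, with a range from 2500 nM to 25000 nM.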

Compound 3, half-maximal inhibitory concentration: 19200 nM
Compound 3: the middle estimate sits 2.4-fold (0.38 log units) below what was measured; the measured number falls inside the stated range.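

In this assay, (4-hydroxybutyl)amino in place of 3-ethylpiperidin-1-yl on the carbonyl carbon gives a 4.9-fold higher number from compound 2 to compound 3 (0.69 log units; beyond the scatter), so this position does respond to the change, and here the open chain is the weaker of the two. This single pair changes the ring, the heavy-atom count and the hydrogen-bond donors together. Nothing measured bears on why the number rises. Open, from the compounds shown here alone, is which of these changes carries the step: a plain butyl chain or an unsubstituted piperidine would each alter only part of it. Going by these compounds, how a carboxylic acid at the chain end would read also remains open.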